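A few compounds are considered here, and "the series" means these few. Any claim that something is new, unique, unknown or untested is made for them only; others in the source may bear on it.

Three compounds have been measured in a functional assay on U-87MG ATCC cells for antiproliferative activity against U-87 MG (Homo sapiens), read by MTT assay, with a stated time of 48 h, tested at 5 uM; a higher number here means a weaker effect of the compound at the concentration tested, a lower number a stronger effect:

Compound 1, `Cc1nc(-c2ccc(Cl)cc2)sc1C(=O)CSc1nc(-c2cccc(Cl)c2)c(C#N)c(=O)[nH]1`, gives 80.2%.
Compound 2, `COc1ccc(-c2nc(SCC(=O)c3sc(-c4ccc(Cl)cc4)nc3C)[nH]c(=O)c2C#N)cc1`, gives 92.1%.
Compound 3, `COc1ccc(-c2nc(SCC(=O)c3sc(-c4ccccc4)nc3C)[nH]c(=O)c2C#N)cc1OC`, gives 80.8%.

Compound 3 stands second highest of the three. Its nearest neighbour is compound 1, whose number is lower by an amount within the usual scatter, so the two cannot be told apart. Compound 2 sits higher than compound 3 by a gap that is beyond the scatter.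

Compound 4, `COc1ccc(-c2nc(SCC(=O)c3sc(-c4ccc(Cl)cc4)nc3C)[nH]c(=O)c2C#N)cc1OC`, differs from compound 3 by chloro in place of hydrogen on an aromatic carbon. Among the measured compounds shown here, the only measured step, a number 11.9 percentage points higher from compound 1 to compound 2 (beyond the scatter), concerns a different replacement, 4-methoxyphenyl in place of 3-chlorophenyl, and so does not bear on the chloro-for-hydrogen change. For the measured compounds named here, no measured pair shows the effect of this change, so the expectation rests on compound 3 alone and is for no step beyond the scatter. Compound 4 is therefore estimated at 81%, within 68% to 94%, which means an expected step of a number 0.2 percentage points higher from compound 3 to compound 4 (within the scatter).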

Compound 4, a percentage reported as activity, at one concentration (the size of the read-out at that concentration, not a potency): 93.4%
The estimate for compound 4 lay 12.4 percentage points below the measured number; the range from low to high includes it.
By their numbers in this assay, from the lowest: compounds 1 and 3 (each within the scatter of the next); then compounds 2 and 4 (each within the scatter of the next).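

In this assay, among the compounds shown here, the step of a number 12.6 percentage points higher from compound 3 to compound 4 (beyond the scatter) is the first measured view of chloro in place of hydrogen at this spot, para to a large group, and it means a weaker effect at the tested concentration for 4-chlorophenyl than for phenyl. With that 4-chlorophenyl kept, methoxy in place of hydrogen on the other aromatic ring gives a number 1.3 percentage points higher from compound 2 to compound 4 (within the scatter) and so barely registers, while 3,4-dimethoxyphenyl in place of 3-chlorophenyl gives a number 13.2 percentage points higher from compound 1 to compound 4 (beyond the scatter) and marks a real loss. No supporting measurement offers an explanation for these shifts.

The chloro step rests on a single pair of compounds, so it may not hold with other groups on the far aromatic ring. Going by these compounds, how an amine or a carboxylic acid would behave at this spot also remains open.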